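The compounds below may be only part of what the source reports. "The series", "measured", "known", "first", "only" and "open" are said of these compounds alone.

Measured compounds:
compound 1 `O=C(Nc1ccccn1)c1ccccc1-c1ccccc1`: 17500 nM
compound 2 `O=C(OCC1CCCN(CCCc2ccccc2)C1)c1ccccc1-c1cccc2ccccc12`: 63100 nM

In an in vitro functional assay on HEK ts201 cells for antagonist activity at Neuronal acetylcholine receptor; alpha3/beta4 (Homo sapiens), read by fluorescence and calcium flux (a lower number here means a stronger inhibitor, a higher number a weaker inhibitor), compound 1 gives 17500 nM, the lower of the two numbers in hand. Compound 2 gives 63100 nM, a higher number that lies beyond the scatter of the assay. Both are weak inhibitors. For the measured compounds named here, no pair of measured compounds differs in a single place, so the size of any one structural change in this assay is not yet known from the series itself.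

Compound 3 `O=C(Nc1ccccc1)c1ccccc1-c1ccccc1` differs from compound 1 by phenyl in place of pyridin-2-yl on an amide-type nitrogen. Going by the values given here, with no comparable step in hand, the step from compound 1 to compound 3 is expected to be small: a 1.1-fold higher number from compound 1 to compound 3 (0.06 log units; within the scatter), without a preferred direction and not clearly beyond the scatter. Compound 3 is therefore estimated at 20000 nM, with a range from 6000 nM to 60000 nM.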

Compound 3, half-maximal inhibitory concentration: 10700 nM
Compound 3: the middle estimate sits 1.9-fold (0.27 log units) above what was measured; the range from low to high includes it.
By their numbers in this assay, from the lowest: compounds 3 and 1 (each within the scatter of the next); then compound 2.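

In this assay the series now has its first step in a single place: a 1.6-fold lower number from compound 1 to compound 3 (0.21 log units; within the scatter) for phenyl in place of pyridin-2-yl on an amide-type nitrogen. On this position, the exchange of a ring with one hydrogen-bond acceptor for a ring of carbon only gives a step that stays within the scatter, so the hydrogen-bond acceptor of pyridin-2-yl is not shown to count for anything in this weak range. Nothing measured on these compounds offers an explanation for this outcome.

Still open, as far as these compounds go, is whether another group on that nitrogen, such as benzyl or a longer chain ending in an amine, gives a step beyond the scatter. Also open, from the compounds shown here alone, is what a methoxy group or a chlorine on the phenyl of compound 3 would do.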